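The source may hold more compounds than are shown below. What is called first, only, known or untested is meant among the compounds shown, and "the series" means these compounds.

Compound 1 `CCCCCCCCCCc1c(C)c(CCCCCCCCCC)c2[n+](c1C)CCC2`: 0.64 uM
Compound 2 `CCCCCCCC/C=C\c1c(C)c(/C=C\CCCCCCCC)c2[n+](c1C)CCC2`: 1.13 uM
Compound 3 `CCCCCCCCCCc1c(C)c(CCCCCCCCCC)c2[n+](c1C)CCCC2`: 0.55 uM

All three values come from a functional assay on PC-3 cells (Homo sapiens) for antiproliferative activity, read by WST assay, with a stated time of 72 h; on this read-out lower numbers stand for an effect already at smaller amounts and higher numbers for an effect only at larger amounts of compound. Compound 2, at 1.13 uM, stands at the upper end of the three numbers. It lies within the usual scatter of compound 1 and just beyond the scatter of compound 3.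

The next compound to be tested is compound 4 `CCCCCCCC/C=C/c1c(C)c(/C=C/CCCCCCCC)c2[n+](c1C)CCC2`. The change from its partner is small: the two compounds have the same atoms and bonds and differ only in configuration as drawn: 2 of 2 stereo elements differ; a double bond is drawn Z in compound 2 and E in compound 4; a double bond is drawn Z in compound 2 and E in compound 4. The two compounds have the same atoms and bonds, but both double bonds are drawn Z in compound 2 and E in compound 4.

Going by the values given here, no measured pair here shows what such a change does, so neither direction can be favoured. The expectation in this assay is therefore no step beyond the scatter, and compound 2 at 1.13 uM serves as the anchor. The expected change is a 1.1-fold lower number from compound 2 to compound 4 (0.05 log units; within the scatter), which stays inside the scatter. Compound 4 is estimated at 1 uM, with an expected range from 0.45 uM to 2.3 uM.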

Compound 4, concentration for half-maximal effect: 0.64 uM
For compound 4 the middle estimate is 1.6-fold (0.19 log units) above the measured one; the measured number falls inside the stated range.
By their numbers in this assay, from the lowest: compounds 3, 1, 4 and 2 (each within the scatter of the next, the first and the last beyond it).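

Going by these compounds alone, compounds 1, 2 and 3 offered no pair that isolated double-bond geometry, whereas this pair does. In this assay, redrawing both double bonds from Z to E gives a 1.8-fold lower number from compound 2 to compound 4 (0.25 log units; within the scatter), so at these two chains the geometry of the double bonds has no effect that can be told apart from ordinary repeat variation. The comparison is a clean one, because nothing else separates the pair: the fact that compounds 2 and 4 differ only in the configuration as drawn

Going by these compounds, both double bonds differ together here, so what each one contributes alone stays unknown, as does the behaviour of a compound with one Z and one E double bond. Also open, on these data alone, is whether the same indifference to geometry would hold for a longer chain, or for a chain carrying a hydroxyl group or a carboxylic acid.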